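Swapping a Pyrrolidine for a Hydroxypiperidine on the Side Chain

The source may report more compounds than this note shows. Statements on the series, on what has been measured and on what is new or still open speak of the compounds shown alone.

Compound 1 `O=C1c2c[n+]([O-])c3ccccc3c2C(=O)c2c1c1ccccc1n2CCN1CCCC1`: 520 nM
Compound 2 `CC1(C)O[C@@H](CO)[C@H](Cn2cc(Cn3c4c(c5ccccc53)C(=O)c3c[n+]([O-])c5ccccc5c3C4=O)nn2)O1`: > 1000 nM
Compound 3 `CC1(C)OC[C@@H](Cn2cc(Cn3c4c(c5ccccc53)C(=O)c3c[n+]([O-])c5ccccc5c3C4=O)nn2)O1`: > 1000 nM

Among the measured compounds shown here, in a functional assay on SH-SY5Y cells (Homo sapiens) for cytotoxicity, read by MTT assay, with a stated time of 72 h (a lower number here means a stronger inhibitor, a higher number a weaker inhibitor), compound 1 gives 520 nM, the only actual number among the three measured compounds. For compound 2 the result is a limit of the assay, > 1000 nM. For compound 3 it is likewise a limit, > 1000 nM. The step that the two limits leave unreadable from compound 2 to compound 3 therefore cannot be read, and it changes a different part of the molecule anyway, so the limit of > 1000 nM in this assay, at which 2 of the 3 values shown sit, gives no guidance here.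

Compound 4 `O=C1c2c[n+]([O-])c3ccccc3c2C(=O)c2c1c1ccccc1n2CCCN1CCC(O)CC1` differs from compound 1 by (4-hydroxypiperidin-1-yl)methyl in place of pyrrolidin-1-yl on a saturated chain carbon, two bonds along the chain from an aromatic nitrogen. For the measured compounds named here, no measured step speaks to this change, so compound 4 is expected to stay within the scatter of compound 1, with a 1.2-fold higher number from compound 1 to compound 4 (0.06 log units; within the scatter) and an estimated value of 600 nM, ranging from 250 nM to 1500 nM.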

Compound 4, half-maximal inhibitory concentration: 130 nM
Estimate against measurement, compound 4: 4.6-fold (0.66 log units) above; measured number outside the range, below it.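

In this assay, putting (4-hydroxypiperidin-1-yl)methyl in place of pyrrolidin-1-yl on a saturated chain carbon, two bonds along the chain from an aromatic nitrogen, gives a 4.0-fold lower number from compound 1 to compound 4 (0.60 log units; beyond the scatter). This place on the side chain therefore accepts the larger group, and the change moves the result beyond the usual scatter. Nothing among the data shown accounts for this step.

On these data alone, the change alters the chain length, ring size and hydroxyl group together, so the part that matters remains open. A 3-(pyrrolidin-1-yl)propyl or 3-(piperidin-1-yl)propyl side chain would help separate these parts.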